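Aniline nitrogen methylation in the indolylmethyl aniline series

The source may hold more compounds than are shown below. What is called first, only, known or untested is meant among the compounds shown, and "the series" means these compounds.

Of the compounds shown here, two have been measured in an assay for inhibition of Amine oxidase [flavin-containing] A (Bos taurus), read by fluorescence; a higher number here means a weaker inhibitor, a lower number a stronger inhibitor. Compound 1 `c1ccc(NCc2cc3ccccc3[nH]2)cc1` gives 10000 nM. Compound 2 `Cn1c(CNc2ccccc2)cc2ccccc21` gives 10 nM, the lowest of the two numbers, with compound 1 the nearest measured neighbour. Among the compounds with values here, the one recorded step, a 1000-fold lower number from compound 1 to compound 2 (3.00 log units; beyond the scatter), is large and lies beyond the scatter.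

Compound 3 `CN(Cc1cc2ccccc2n1C)c1ccccc1` differs from compound 2 by methyl in place of hydrogen on a nitrogen on an aromatic ring. Within the data shown here, the recorded step from compound 1 to compound 2 also exchanged hydrogen for methyl on a nitrogen, but on the aromatic nitrogen of the shared core rather than on the nitrogen carrying the phenyl and the chain carbon, so it bears on the present change only loosely; no measured pair speaks to methylation of this nitrogen. The expectation for compound 3 is therefore a step of modest size in this assay, in either direction, a 2.5-fold higher number from compound 2 to compound 3 (0.40 log units; beyond the scatter), with wide uncertainty. Compound 3 is estimated at 25 nM, between 3 nM and 250 nM.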

Compound 3, inhibition constant: 6 nM
Beside the measured number, compound 3's estimate is 4.2-fold (0.62 log units) above it; low and high end bracket the measured number.
By their numbers in this assay, from the lowest: compounds 3 and 2 (each within the scatter of the next); then compound 1.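

In this assay methyl in place of hydrogen on this nitrogen gives a 1.7-fold lower number from compound 2 to compound 3 (0.22 log units; within the scatter), so in this series the hydrogen on this nitrogen is not required for a number as low as that of compound 2. This differs from the exchange of hydrogen for methyl on the aromatic nitrogen of the shared core, which gave a 1000-fold lower number from compound 1 to compound 2 (3.00 log units; beyond the scatter); the same exchange therefore has a very different outcome at the two nitrogens. No supporting measurement bears on this result.

The compounds shown leave open whether an ethyl group, a longer chain or an acetyl group on this nitrogen would hold the number at this level. Also open, going by these compounds, is whether methyl on this nitrogen, with hydrogen kept on the aromatic nitrogen of the shared core, would give any of the low number seen with compound 2.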